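The compounds below may be only part of what the source reports. "The series", "measured", "known", "first", "only" and "open" are said of these compounds alone.

Compound 1 `Cc1nnc(SCc2ccccc2)n1N1C(=O)c2ccccc2C1=O` in a functional assay on PC-3M cells (Homo sapiens) for cytotoxicity, read by MTT assay, with a stated time of 48 h (a higher number here means a weaker inhibitor, a lower number a stronger inhibitor), gives > 200000 nM, a limit of the assay.
Compound 2 `Cc1nnc(SCC(=O)c2ccc(Cl)cc2)n1N1C(=O)c2ccccc2C1=O` in this assay gives > 200000 nM, also a limit.
Compound 3 `CCc1nnc(SCc2ccccc2)n1N1C(=O)c2ccccc2C1=O` in this assay gives > 200000 nM, again a limit.

Compound 3 thus stands at the limit, and the two other values shown sit there as well (the limit of > 200000 nM in this assay, at which 3 of the 3 values shown sit). Compound 4 `CCc1nnc(SCC(=O)c2ccc(C)cc2)n1N1C(=O)c2ccccc2C1=O` differs from compound 3 in that a ((4-methylphenyl)carbonyl in place of phenyl on a saturated chain carbon bound to a sulfur). The measured steps that bear on this change are a step that the two limits leave unreadable from compound 1 to compound 2 and a step that the two limits leave unreadable from compound 1 to compound 3, neither of which has a readable size. With every value shown a limit, no direction can be read from them. Compound 4 is therefore expected to give another limit in this assay, and the step that the limit leaves unreadable from compound 3 to compound 4 is estimated to be none beyond the scatter. The estimate for compound 4 is 300000 nM with a range from 120000 nM to 1000000 nM.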

Compound 4, half-maximal inhibitory concentration: > 200000 nM
Compound 4: no number, only a limit; the forecaster's own chance of this, stated with the estimate: 85%; the middle value lies beyond the limit too.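

Among these compounds, compound 3 and compound 4 both stand only at a limit of the assay, so no step between them can be read: the limit of > 200000 nM in this assay, at which 4 of the 4 values shown sit. The compounds shown leave open which change, if any, would give a readable value in this assay within this series.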